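Replacing 4-chlorophenyl with hydroxy on compound 1

A few compounds are considered here, and "the series" means these few. Any claim that something is new, unique, unknown or untested is made for them only; others in the source may bear on it.

Measured so far in an ADME assay on L1210/0 cells (Mus musculus) for cytotoxicity, with a stated time of 48 h; on this read-out lower numbers stand for stronger inhibition and higher numbers for weaker inhibition
- compound 1 (`OC[C@H]1C[C@@H](Cn2cnc3c(-c4ccc(Cl)cc4)ncnc32)c2ccccc21`) with 8440 nM
- compound 2 (`Nc1ccn([C@@H]2O[C@H](CO)[C@H](F)[C@@H]2O)c(=O)n1`) with 159000 nM
- compound 3 (`O=c1[nH]c(=O)n([C@H]2C[C@H](O)[C@@H](CO)O2)cc1/C=C/Cl`) with > 200000 nM as a limit of the assay

Of the two actual numbers, compound 1 has the lower, and compound 2 lies higher by more than the scatter. Compound 4 (`OC[C@H]1C[C@@H](Cn2cnc3c(O)ncnc32)c2ccccc21`) carries hydroxy in place of 4-chlorophenyl on an aromatic carbon. Among the compounds with values here, no measured pair shows such a change, so the expectation rests on the structures alone. A move to a higher number in this assay is expected, meaning weaker inhibition, beyond the scatter. The expected size is a 12-fold higher number from compound 1 to compound 4 (1.07 log units; beyond the scatter) by this estimate. Compound 4 is estimated at 100000 nM with an expected range (30000 nM to 200000 nM).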

Compound 4, half-maximal inhibitory concentration: > 200000 nM
Compound 4: a limit, no number; the forecaster's own chance of this, stated with the estimate: 45%; at least 2.0-fold (0.30 log units) between middle value and limit.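

In this assay, the only step shown at this aromatic carbon of the shared core is an at least 23-fold higher number from compound 1 to compound 4 (1.37 log units; beyond the scatter), so hydroxy in place of 4-chlorophenyl weakens inhibition well beyond the scatter. Compound 4 gives > 200000 nM, which is a limit of the assay and not a number, so the step has a lower bound but no known full size: the limit of > 200000 nM in this assay, at which 2 of the 4 values shown sit.

From the compounds shown here alone, whether the chlorine or the aromatic ring of 4-chlorophenyl carries the difference stays open. So does whether an amine, a methyl group or an unsubstituted phenyl at this carbon would retain inhibition.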